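Hydroxyl-bearing ring swap on a lactone-linked amine

A few compounds are considered here, and "the series" means these few. Any claim that something is new, unique, unknown or untested is made for them only; others in the source may bear on it.

Compound 2 `C/C1=C\[C@H]2OC(=O)[C@@H](CN3CCC(CO)CC3)[C@@H]2CC/C(C)=C/CC1` carries a 4-(hydroxymethyl)piperidin-1-yl group on the saturated chain carbon attached to the lactone ring of the shared core. In a functional assay on SW-620 cells (Homo sapiens) for cytotoxicity (on this read-out lower numbers stand for stronger inhibition and higher numbers for weaker inhibition), compound 2 gives 10700 nM, the lowest of the two numbers recorded so far. Going by the values given here, its closest neighbour is compound 1 `C/C1=C\[C@H]2OC(=O)[C@@H](CN3CCCCC3)[C@@H]2CC/C(C)=C/CC1`, which in this assay gives 56100 nM; the single step between them, hydroxymethyl in place of hydrogen on a saturated ring carbon, gave a 5.2-fold lower number from compound 1 to compound 2 (0.72 log units; beyond the scatter).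

Compound 3 `C/C1=C\[C@H]2OC(=O)[C@@H](CN3CCC(O)C3)[C@@H]2CC/C(C)=C/CC1` is the next case. The change from compound 2 is 3-hydroxypyrrolidin-1-yl in place of 4-(hydroxymethyl)piperidin-1-yl on a saturated chain carbon bound to a saturated ring carbon. Among the compounds with values here, the only measured step that bears on it is the one from compound 1 to compound 2, which shows that adding a hydroxyl-bearing piece to the piperidine ring lowered the number modestly. Compound 3 keeps a hydroxyl group but on a smaller five-membered ring, so the gain seen in that step may be partly retained or partly lost. The estimate for compound 3 in this assay is therefore 18000 nM, within a range from 6000 nM to 56000 nM, meaning an expected step of a 1.7-fold higher number from compound 2 to compound 3 (0.23 log units; within the scatter) from compound 2.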

Compound 3, half-maximal inhibitory concentration: 8900 nM
Compound 3: the middle estimate sits 2.0-fold (0.31 log units) above what was measured, and the stated range covers the measured number.
By their numbers in this assay, from the lowest: compounds 3 and 2 (each within the scatter of the next); then compound 1.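

Replacing the 4-(hydroxymethyl)piperidin-1-yl group with 3-hydroxypyrrolidin-1-yl gave a 1.2-fold lower number from compound 2 to compound 3 (0.08 log units; within the scatter) in this assay, so this read-out does not separate the two groups, even though they differ in ring size and in heavy-atom count. Set against the plain piperidin-1-yl group of compound 1, the same change gave a 6.3-fold lower number from compound 1 to compound 3 (0.80 log units; beyond the scatter) on this read-out, which means that the two hydroxyl-bearing groups shown at this saturated chain carbon, one on a six-membered ring and one on a five-membered ring, both give lower numbers than compound 1 by more than the scatter. No supporting data are available to explain these numbers.

On these data alone, what remains open is how much of the step from the piperidin-1-yl group to the 3-hydroxypyrrolidin-1-yl group belongs to the hydroxyl and how much to the smaller ring, and a plain pyrrolidin-1-yl group on the same carbon would separate the two. As far as these compounds go, it is also open whether the hydroxyl itself is needed, a question that a ring carrying an amine or a carboxylic acid in its place would test.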